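The source may report more compounds than this note shows. Statements on the series, on what has been measured and on what is new or still open speak of the compounds shown alone.

Three compounds sharing one core were tested in an assay for inhibition of 15-hydroxyprostaglandin dehydrogenase [NAD(+)] (Homo sapiens), read by fluorescence, with a stated time of 15 min, in the presence of a further agent that is not named here; on this read-out lower numbers stand for stronger inhibition and higher numbers for weaker inhibition. Compound 1 `CCCC[S+]([O-])c1sc2nc(-c3nccs3)cc(-c3ccc(C(C)(C)O)cc3)c2c1N` gives 3.6 nM in this assay, compound 2 `CCCC[S+]([O-])c1sc2nc(-c3nccs3)cc(-c3ccc(COC(=O)NCC)cc3)c2c1N` gives 3.4 nM, and compound 3 `CCCC[S+]([O-])c1sc2nc(-c3nccs3)cc(-c3ccc(CCO)cc3)c2c1N` gives 2.9 nM. Compound 3 carries the lowest of the three numbers, yet the steps leading to it, a 1.2-fold lower number from compound 1 to compound 3 (0.09 log units; within the scatter) and a 1.2-fold lower number from compound 2 to compound 3 (0.07 log units; within the scatter), both lie within the scatter, as does a 1.1-fold lower number from compound 1 to compound 2 (0.02 log units; within the scatter); on these numbers the three compounds cannot be separated. The unmeasured compound 4 `CCCC[S+]([O-])c1sc2nc(-c3nccs3)cc(-c3ccc(CN)cc3)c2c1N` differs from compound 3 in a single place: amino in place of hydroxymethyl on a saturated chain carbon bound to an aromatic carbon. Two of the measured steps bear on this change. The step of a 1.2-fold lower number from compound 2 to compound 3 (0.07 log units; within the scatter) swaps a group on the same saturated chain carbon bound to an aromatic carbon, and a 1.2-fold lower number from compound 1 to compound 3 (0.09 log units; within the scatter) reshapes the group on the same aromatic carbon; neither moved the number beyond the scatter. Since every exchange in this part of the molecule so far has left the reading unchanged within the scatter, compound 4 is expected to behave alike, with an estimated step of a 1.1-fold higher number from compound 3 to compound 4 (0.04 log units; within the scatter). The estimate for compound 4 in this assay is therefore 3.2 nM, with a range from 1.2 nM to 9 nM.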

Compound 4, half-maximal inhibitory concentration: 11.5 nM
Estimate against measurement, compound 4: 3.6-fold (0.56 log units) below; measured number above the stated range.
By their numbers in this assay, from the lowest: compounds 3, 2 and 1 (each within the scatter of the next); then compound 4.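

Among these compounds, this is the first change at this saturated chain carbon bound to an aromatic carbon that moves the number in this assay beyond the scatter: amino in place of hydroxymethyl gives a 4.0-fold higher number from compound 3 to compound 4 (0.60 log units; beyond the scatter). The other two comparisons point the same way, with a 3.4-fold higher number from compound 2 to compound 4 (0.53 log units; beyond the scatter) and a 3.2-fold higher number from compound 1 to compound 4 (0.50 log units; beyond the scatter), so 4-(aminomethyl)phenyl stands apart from the three groups that could not be separated from one another, and this part of the molecule is shown not to be indifferent to every exchange. The counts under comparison do not separate hydroxymethyl from amino, since each brings one hydrogen-bond donor, one hydrogen-bond acceptor and no net charge, and no measurement at hand bears on why the number rises.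

On these data alone, whether the higher number goes with the nitrogen or with the shorter chain stays open, as compound 4 differs from compound 3 in both, and a 2-aminoethyl group would tell the two apart. As far as these compounds go, how an acetamide or a carboxylic acid in the same place would read also remains open.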